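A few compounds are considered here, and "the series" means these few. Any claim that something is new, unique, unknown or untested is made for them only; others in the source may bear on it.

Compound 1 `Cc1cccc(N2CCN(CCCNc3nc(NCc4ccco4)c4ccccc4n3)CC2)c1C` and compound 2 `Cc1cccc(N2CCN(CCCNc3nc(NCc4ccco4)c4cc(F)ccc4n3)CC2)c1C` share a core and differ in one place, namely (hydrogen in place of fluoro on an aromatic carbon). In a functional assay on A375P cells (Homo sapiens) for cytotoxicity, read by MTT assay, with a stated time of 2 days (a higher number here means a weaker inhibitor, a lower number a stronger inhibitor), compound 2 gives 2830 nM, and compound 1 gives 3040 nM. The step of a 1.1-fold higher number from compound 2 to compound 1 (0.03 log units; within the scatter) is small, and the two numbers cannot be told apart on this evidence.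

Compound 3 `CCN(CC)CCNc1nc(NCc2ccco2)c2cc(F)ccc2n1` carries the fluorinated core of compound 2, but the side chain on the other amine is different, and the difference between the two cores is not broken down here. For compound 3 the entry in this assay reads "not determined" (no result reported), so no result was reported.

Compound 4 `CCN(CC)CCNc1nc(NCc2ccco2)c2ccccc2n1` stands to compound 3 exactly as compound 1 stands to compound 2: hydrogen in place of fluoro on an aromatic carbon. The place lines of the two changes read the same word for word, so this is the same change made on a second pair. The step of a 1.1-fold higher number from compound 2 to compound 1 (0.03 log units; within the scatter) lies within the scatter. On that basis the step from compound 3 to compound 4 in this assay is expected to be about as small. The number for compound 3 is missing, so there is no anchor for compound 4, and only the two measured compounds, which both sit near the low-micromolar range, give any footing.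

Compound 4 is therefore estimated at 6000 nM, with the plausible range set wide, from 1500 nM to 30000 nM. On these data alone, the range is wide because only compound 2 with 2830 nM and compound 1 with 3040 nM inform it and the side chain of compound 4 is untested here.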

Compound 4, half-maximal inhibitory concentration: 34900 nM
For compound 4 the middle estimate is 5.8-fold (0.76 log units) below the measured one, and the stated range ends below it.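

In this assay compound 3 has no single number, so the step from compound 3 to compound 4 cannot be read and the result for compound 4 gives no new comparison. Nothing shown here bears on that result. The compounds shown leave open whether hydrogen in place of fluoro has as small an effect with the side chain of compound 4 as it has between compound 2 and compound 1.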